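Extending the Acid Chain in a Weakly Inhibiting Series

A few compounds are considered here, and "the series" means these few. Any claim that something is new, unique, unknown or untested is made for them only; others in the source may bear on it.

Compound 1 `CCCCn1nc(-c2ccccc2)c(-c2ccccc2)cc1=O` gives 176000 nM in an assay on microsomes from liver for inhibition of sterol O-acyltransferase 1 (Rattus norvegicus); a lower number here means a stronger inhibitor, a higher number a weaker inhibitor. Compound 2 `CCCCCCCn1nc(-c2ccccc2)c(-c2ccccc2)cc1=O` gives 86000 nM. Compound 3 `O=C(O)CCCCCCn1nc(-c2ccccc2)c(-c2ccccc2)cc1=O` gives only a limit, > 300000 nM.

Compound 3 thus stands at the weak end of what was measured, with only a limit and no number (the limit of > 300000 nM in this assay, at which 1 of the 3 values shown sits). Compound 4 `O=C(O)CCCCCCCn1nc(-c2ccccc2)c(-c2ccccc2)cc1=O` differs from it by carboxymethyl in place of carboxy on a saturated chain carbon, six bonds along the chain from an aromatic nitrogen. Among the measured compounds shown here, two measured steps bear on this. Lengthening the chain gave a 2.0-fold lower number from compound 1 to compound 2 (0.31 log units; beyond the scatter), while placing the acid at the chain end gave an at least 3.4-fold higher number from compound 2 to compound 3 (0.54 log units; beyond the scatter) and an at least 1.7-fold higher number from compound 1 to compound 3 (0.23 log units; that floor lies within the scatter). Moving the acid one carbon further out is expected to change little, if anything beyond the scatter. Compound 4 is therefore estimated at 300000 nM, within 120000 nM to 800000 nM. The expected step is a number no higher from compound 3 to compound 4 (the limit leaves the size open).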

Compound 4, half-maximal inhibitory concentration: > 300000 nM
Compound 4: a limit, no number (the forecaster's own chance of this, stated with the estimate: 55%); the middle value lies on the limit itself.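

Compound 4, like compound 3, gives only a limit, so the step between them cannot be read: the limit of > 300000 nM in this assay, at which 2 of the 4 values shown sit. Carboxymethyl in place of carboxy, six bonds along the chain from an aromatic nitrogen, therefore did not bring this acid series to a readable number in this assay. Against the chains without the acid, an at least 3.4-fold higher number from compound 2 to compound 4 (0.54 log units; beyond the scatter) and an at least 1.7-fold higher number from compound 1 to compound 4 (0.23 log units; that floor lies within the scatter) are the steps that can be read.

On these data alone, how far compound 3 and compound 4 lie past the limit stays open. Also open, as far as these compounds go, is whether a methyl ester or an amide at the chain end would give a number.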